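Swapping the amide head group in a chemokine receptor series

This account rests on a few compounds, and the source may have more. Where it says the series, first, only, none or still open, it means among the compounds named here.

Measured so far:
Compound 1 `O=C(NCc1ccc(CNS(=O)(=O)c2ccc(F)cc2F)cc1)c1cncnc1` — 1 nM
Compound 2 `O=C(NCc1ccc(CNS(=O)(=O)c2ccc3c(c2)CCO3)cc1)c1scc2c1OCCO2` — 10 nM
Compound 3 `O=C(NCc1ccc(CNS(=O)(=O)c2ccc(F)cc2F)cc1)c1ncc[nH]1` — > 1000 nM

All three compounds share a core in which a carbonyl carbon carries a different ring group, and all were tested in an assay on cells for displacement of a labelled ligand from C-X-C chemokine receptor type 4 (Homo sapiens), read by fluorescence and microscopy, with stated times of 10 min and 30 min; a lower number here means that less compound is needed, a higher number that more compound is needed for the effect. Compound 1 gives 1 nM in this assay. Compound 2 gives 10 nM, the higher of the two numbers available. For compound 3 the assay reports only a limit, > 1000 nM, rather than a number.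

The next compound, compound 4 `O=C(NCc1ccc(CNS(=O)(=O)c2ccc3c(c2)CCO3)cc1)c1cc2ccccn2n1`, changes compound 2 at the same carbonyl carbon: a group of 9 heavy atoms (7 carbon, 2 nitrogen; one five-membered aromatic ring with 2 hetero atoms, one six-membered aromatic ring with 1 hetero atom) in place of a group of 9 heavy atoms (6 carbon, 2 oxygen, 1 sulfur; one five-membered aromatic ring with 1 hetero atom, one six-membered non-aromatic ring with 2 hetero atoms), on a carbonyl carbon. Within the data shown here, only one measured step touches that position. In an at least 1000-fold higher number from compound 1 to compound 3 (3.00 log units; beyond the scatter) the change was drastic, and the value of compound 3 sits at the limit of > 1000 nM in this assay, at which 1 of the 3 values shown sits. That step replaced an aromatic ring with pyrimidin-5-yl by 1H-imidazol-2-yl, a group bearing a hydrogen-bond donor, whereas the group entering compound 4 has no hydrogen-bond donor, so that step is only a loose guide here. Against this background, a modest rise in the number is expected for compound 4, as a 3.0-fold higher number from compound 2 to compound 4 (0.48 log units; beyond the scatter). The estimate for compound 4 is therefore 30 nM, within a range of 5 nM to 300 nM.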

Compound 4, effective concentration (reported as EC, without a stated level of effect): 1 nM
Estimate against measurement, compound 4: 30-fold (1.48 log units) above, and the stated range ends above it.
By their numbers in this assay, from the lowest: compounds 1 and 4 (each within the scatter of the next); then compound 2. At a limit, above all of these: compound 3.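

At this carbonyl carbon, a change of head group can lower the number as well as raise it: this assay shows a 10-fold lower number from compound 2 to compound 4 (1.00 log units; beyond the scatter). The group that leaves and the group that enters both count 9 heavy atoms and 0 hydrogen-bond donors, so this step changes neither of those counts; it does change the atoms and rings, with two nitrogens and two aromatic rings in the entering group in place of oxygen, sulfur and a non-aromatic ring. Compound 3, with 1H-imidazol-2-yl at this place, still gives no number, only a limit: the limit of > 1000 nM in this assay, at which 1 of the 4 values shown sits.

From the compounds shown here alone, the two steps at this position start from different cores, one from compound 1 and the other from compound 2, so it remains open whether a head group keeps its effect when moved from one core to the other. Going by these compounds, how a plain phenyl ring or an open chain such as propyl would compare on this carbonyl carbon also remains open.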